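The source may report more compounds than this note shows. Statements on the series, on what has been measured and on what is new or still open speak of the compounds shown alone.

Among the compounds with values here, compound 1, `COc1cc(Cl)cc(-c2nn(-c3cccc(NC(=O)Nc4cccc(C(F)(F)F)c4)c3)cc2-c2ccncc2)c1`, is one of three compounds measured in a functional assay on MDA-MB-435 cells (Homo sapiens) for inhibition, read by sulforhodamine B assay, with a stated time of 48 h, tested at 10 uM; a lower number here means a stronger effect, a higher number a weaker effect of the compound at the concentration tested. Compound 1 gives -20.9%, the lowest of the three numbers. Compound 2, `COc1cc(Cl)cc(-c2nn(-c3cccc(NC(=O)Nc4ccc(Cl)c(C(F)(F)F)c4)c3)cc2-c2ccncc2)c1`, gives -16.8%; the step of a number 4.1 percentage points higher from compound 1 to compound 2 (within the scatter) lies within the scatter. Compound 3, `COc1cc(Cl)cc(-c2nn(-c3cccc(NC(=O)c4cc(C(F)(F)F)cc(C(F)(F)F)c4)c3)cc2-c2ccncc2)c1`, gives 80%, a number far beyond the scatter from compound 1.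

Compound 4, `COc1cc(Cl)cc(-c2nn(-c3cccc(NC(=O)c4ccc(Cl)c(Cl)c4)c3)cc2-c2ccncc2)c1`, has not been measured. It differs from compound 1 by 3,4-dichlorophenyl in place of (3-(trifluoromethyl)phenyl)amino on a carbonyl carbon. Within the data shown here, the only step between measured compounds, a number 4.1 percentage points higher from compound 1 to compound 2 (within the scatter), concerns a single chloro and does not bear on this change. Compound 3 does bear on it: in compound 3 the carbonyl carbon is likewise joined directly to an aromatic ring rather than through an amino group, and compound 3 gives 80% while compound 1 gives -20.9%. A large rise is therefore expected in this assay, with the step of a number 75.9 percentage points higher from compound 1 to compound 4 (beyond the scatter) estimated. Compound 4 is expected to give 55%, within a range from 5% to 95%.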

Compound 4, a percentage reported as activity, at one concentration (the size of the read-out at that concentration, not a potency): 80.8%
Beside the measured number, compound 4's estimate is 25.8 percentage points below it; low and high end bracket the measured number.
By their numbers in this assay, from the lowest: compounds 1 and 2 (each within the scatter of the next); then compounds 3 and 4 (each within the scatter of the next).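

Putting 3,4-dichlorophenyl in place of the aryl amino group on this carbonyl carbon gives a number 101.7 percentage points higher from compound 1 to compound 4 (beyond the scatter) in this assay, and the same kind of change from the chlorinated partner gives a number 97.6 percentage points higher from compound 2 to compound 4 (beyond the scatter), so the effect becomes much weaker in both pairs. Compound 3 alone could not show whether its high number went with its trifluoromethyl groups, but compound 4 carries none and gives 80.8%, within the scatter of compound 3 at 80%. Among these four compounds, both with the amino link give low numbers and both with the ring directly on the carbonyl carbon give high numbers, with none going against this. No measurement shown explains this difference. Going by these compounds, it remains open how a methyl group, a longer carbon chain or a benzylamino group on this carbonyl carbon would behave.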